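Methyl-to-hydrogen change on a distal phenyl ring, cytotoxicity

This account rests on a few compounds, and the source may have more. Where it says the series, first, only, none or still open, it means among the compounds named here.

Measured compounds:
compound 1 `COc1cc(-c2cc(COCc3cn(Cc4cc(-c5ccccc5)cnc4Cl)nn3)on2)cc(OC)c1OC` — 112000 nM
compound 2 `COc1cc(-c2cc(COCc3cn(Cc4cc(-c5ccc(C)cc5)cnc4Cl)nn3)on2)cc(OC)c1OC` — 30600 nM
compound 3 `COc1cc(COCc2cn(Cc3cc(-c4ccc(C)cc4)cnc3Cl)nn2)cc(OC)c1OC` — 150000 nM

Three compounds were tested in a functional assay on A549 cells (Homo sapiens) for cytotoxicity, read by MTT assay, with a stated time of 48 h; on this read-out higher numbers stand for weaker inhibition and lower numbers for stronger inhibition. In this assay compound 2 gives 30600 nM, compound 1 gives 112000 nM and compound 3 gives 150000 nM. Compound 1 and compound 2 share one core, and the difference between them is hydrogen in place of methyl on an aromatic carbon; this step gives a 3.7-fold higher number from compound 2 to compound 1 (0.56 log units; beyond the scatter). The difference between the core of compound 3 and the core of compound 2 is not broken down here. The number for compound 3 sits near that of compound 1 and is well apart from that of compound 2.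

Compound 4 `COc1cc(COCc2cn(Cc3cc(-c4ccccc4)cnc3Cl)nn2)cc(OC)c1OC` is the not yet measured partner of compound 3: it carries the same kind of change, hydrogen in place of methyl on an aromatic carbon, on the core of compound 3. Since the matching step from compound 2 to compound 1 gave a 3.7-fold higher number from compound 2 to compound 1 (0.56 log units; beyond the scatter), a step of similar direction is expected here, so that compound 4 is estimated to give a 3.0-fold higher number from compound 3 to compound 4 (0.48 log units; beyond the scatter) in this assay. Compound 4 is therefore expected to give 450000 nM, with an expected range from 150000 nM to 1200000 nM, though a number this high may fall outside what the assay resolves.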

Compound 4, half-maximal inhibitory concentration: 62600 nM
The estimate for compound 4 lay 7.2-fold (0.86 log units) above the measured number, outside the stated range (below it).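

In this assay, the 4-methylphenyl to phenyl change now gives a 2.4-fold lower number from compound 3 to compound 4 (0.38 log units; beyond the scatter), so the step seen on the first core does not carry over to the second, and the two steps run in opposite directions: the same change on two cores in this assay, a 3.7-fold higher number (0.56 log units; beyond the scatter) from compound 2 to compound 1 and a 2.4-fold lower number (0.38 log units; beyond the scatter) from compound 3 to compound 4, 8.8-fold (0.94 log units) apart, beyond the scatter of two such steps

Within these four compounds, then, the outcome of this one change depends on the core that carries it, and the step on one core does not give even the direction of the step on the other. Among these compounds, this does not show why the two cores part, and with only one matched pair on each core it says nothing about how the same change would run on any third core or in any other test.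

The compounds shown leave open whether this reversal belongs to methyl alone or would also appear with another group in its place, such as a fluorine atom, a methoxy group, an amine or a carboxylic acid. They also leave open which part of the difference between the core of compound 1 and the core of compound 3 goes with the change of direction, as that difference is not broken down into single steps.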